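The source may hold more compounds than are shown below. What is called first, only, known or untested is meant among the compounds shown, and "the series" means these compounds.

Compound 1 `COc1cc(OC)c(OC)cc1/C=C/C(=O)c1ccc(-c2c[nH]cn2)cc1`: 1.97 ug/mL
Compound 2 `COc1cc(OC)c(OC)cc1/C=C/C(=O)c1ccc([N+](=O)[O-])cc1`: 1.98 ug/mL

In a functional assay, read by Griess assay, with a stated time of 2.5 h (on this read-out higher numbers stand for weaker inhibition and lower numbers for stronger inhibition), compound 2 gives 1.98 ug/mL, level with compound 1 within the usual scatter. Within the data shown here, only one measured step bears on what comes next, and it sits at the same place on the molecule: a 1.0-fold higher number from compound 1 to compound 2 (0.00 log units; within the scatter). Exchanging those two groups therefore left the number where it was. Compound 3 `COc1cc(OC)c(OC)cc1/C=C/C(=O)c1ccc(Br)cc1` keeps the shared core and changes that place again: bromo in place of nitro on an aromatic carbon. Among the measured compounds shown here, no compound with a bromo group has been measured yet, and a single step cannot establish a trend, so this expectation rests on thin evidence. With compound 1 and compound 2 so close, no shift beyond the scatter is expected, and the estimated change is a 1.0-fold higher number from compound 2 to compound 3 (0.00 log units; within the scatter). For compound 3 the estimate is 2 ug/mL, with an expected range of 0.9 ug/mL to 4.2 ug/mL.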

Compound 3, half-maximal inhibitory concentration: 2.22 ug/mL
For compound 3 the middle estimate is 1.1-fold (0.05 log units) below the measured one; the range from low to high includes it.
By their numbers in this assay, from the lowest: compounds 1, 2 and 3 (each within the scatter of the next).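

In this assay, replacing nitro with bromo gives a 1.1-fold higher number from compound 2 to compound 3 (0.05 log units; within the scatter) and so stays within the scatter, although the entering group has one heavy atom and no hydrogen-bond acceptors while the leaving group has three heavy atoms and two acceptors. Replacing the ring-bearing 1H-imidazol-4-yl with the single bromine atom gives a 1.1-fold higher number from compound 1 to compound 3 (0.05 log units; within the scatter) and also stays within the scatter, so three quite different groups at this place on the six-membered aromatic ring now give matching numbers. No measurement available here explains why these numbers stay level.

From the compounds shown here alone, it remains open whether an amine, a carboxylic acid or a longer chain at this place would also stay within the scatter. A plain hydrogen there would show whether having any of these groups matters at all.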